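Extending the hydroxyethoxy chain on an inactive core

The source may report more compounds than this note shows. Statements on the series, on what has been measured and on what is new or still open speak of the compounds shown alone.

Measured compounds:
- compound 1, `Oc1[nH]nc2nnc(-c3ccccc3)c(-c3ccccc3)c12`: > 100000 nM
- compound 2, `Cc1n[nH]c2nnc(N)c-2c1C`: "not determined" (no result reported)
- compound 3, `Nc1nn(COCCO)c2nnc(-c3ccccc3)c(-c3ccccc3)c12`: > 100000 nM

In a functional assay on PC-3 cells (Homo sapiens) for cytotoxicity (on this read-out lower numbers stand for stronger inhibition and higher numbers for weaker inhibition), compound 1 gives only a limit, > 100000 nM. For compound 2 no result was recorded in this assay, "not determined" (no result reported). Compound 3 also gives only a limit in this assay, > 100000 nM. So for compound 3 no number is known, only that it sits at the limit of > 100000 nM in this assay, at which 2 of the 3 values shown sit, the same limit as for compound 1, and no comparison between the two can be drawn.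

Compound 4, `Nc1nn(CCOCCO)c2nnc(-c3ccccc3)c(-c3ccccc3)c12`, is the next compound to be measured in this assay. It differs from compound 3 by (2-hydroxyethoxy)methyl in place of 2-hydroxyethoxy on a saturated chain carbon bound to an aromatic nitrogen; the chain grows by one carbon while its donor and acceptor count stays the same. Going by the values given here, since both limits shown sit at the top of the assay and no measured step exists for comparison, no change beyond the scatter is expected, and compound 4 is expected to remain at the limit, with a step that the limit leaves unreadable from compound 3 to compound 4 as the estimated step. The estimate for compound 4 is 150000 nM, in a range from 50000 nM to 500000 nM.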

Compound 4, half-maximal inhibitory concentration: > 100000 nM
Compound 4 ended at the assay's limit; the forecaster's own chance of this, stated with the estimate: 85%; the middle value is on the limit's open side.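

Compound 3 and compound 4 both stop at a limit of the assay rather than a number, so no step between them can be read, because neither has a measured value: the limit of > 100000 nM in this assay, at which 3 of the 4 values shown sit.

Still open, going by these compounds, is how strongly compound 3 and compound 4 act in this assay and whether they differ at all.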